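The compounds below may be only part of what the source reports. "The series", "measured", "known", "first", "only" and "open" are said of these compounds alone.

Measured so far in a functional assay on HepG2 cells (Homo sapiens) for antiproliferative activity, read by MTT assay; a lower number here means a stronger inhibitor, a higher number a weaker inhibitor:
compound 1 `CNC(=O)c1ccc(Oc2cccc(NC(=S)Nc3ccc(F)cc3)c2)nc1`: 42500 nM
compound 2 `CNC(=O)c1ccc(Oc2cccc(NC(=S)Nc3cc(C(F)(F)F)cc(C(F)(F)F)c3)c2)nc1`: 4550 nM
compound 3 `CNC(=O)c1ccc(Oc2cccc(NC(=S)Nc3ccc(OC(F)(F)F)cc3)c2)nc1`: a limit of the assay, > 100000 nM

Compound 1 holds the higher of the two numbers; compound 2 sits well below it, beyond the scatter. Compound 3 gives only (the limit of > 100000 nM in this assay, at which 1 of the 3 values shown sits), not a number.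

Compound 4 `CNC(=O)c1ccc(Oc2cccc(NC(=S)Nc3ccc(F)c(Cl)c3)c2)nc1` differs from compound 1 by chloro in place of hydrogen on an aromatic carbon. For the measured compounds named here, the only one-place step recorded on that ring, an at least 2.3-fold higher number from compound 1 to compound 3 (0.37 log units; beyond the scatter), went the weaker way, whereas compound 2 with two trifluoromethyl groups on that ring gives the lowest number. Going by the values given here, no step with added chloro is known here, so the expectation rests loosely on these two. A modest step downward is expected, a 2.1-fold lower number from compound 1 to compound 4 (0.33 log units; beyond the scatter), giving for compound 4 an estimate of 20000 nM, within 6000 nM to 60000 nM.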

Compound 4, half-maximal inhibitory concentration: > 100000 nM
Compound 4 was reported as a limit; the forecaster's own chance of this, stated with the estimate: 10%; middle value at least 5.0-fold (0.69 log units) away from the limit.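

In this assay, chloro ortho to the fluoro group, turning 4-fluorophenyl into 3-chloro-4-fluorophenyl, gives an at least 2.3-fold higher number from compound 1 to compound 4 (0.37 log units; beyond the scatter). Compound 4 gives only a limit of the assay, > 100000 nM, so this step has a bound and no exact size. A single added chloro on this ring is thus enough to reach the limit, which compound 3 also reaches after a different one-place change: the limit of > 100000 nM in this assay, at which 2 of the 4 values shown sit.

Still open, as far as these compounds go, is whether methyl, methoxy or an amino group on this carbon gives a readable number. Also open, from the compounds shown here alone, is whether chloro behaves alike on a ring without the fluoro group.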